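Notes on the ring amine substituent of compound 3

This account rests on a few compounds, and the source may have more. Where it says the series, first, only, none or still open, it means among the compounds named here.

Compound 3 `NC(=O)c1c(NC(=O)c2cccc([N+](=O)[O-])c2)sc2c1CCN(Cc1ccc(Cl)cc1Cl)C2` gives 33000 nM in a functional assay on HeLa cells (Homo sapiens) for antiproliferative activity, with a stated time of 24 h; on this read-out higher numbers stand for weaker inhibition and lower numbers for stronger inhibition. Compound 1 `NC(=O)c1c(NC(=O)c2ccccc2Cl)sc2c1CCN(Cc1ccc(Cl)cc1Cl)C2` gives 21100 nM, and the step of a 1.6-fold higher number from compound 1 to compound 3 (0.19 log units; within the scatter) lies within the scatter. Compound 2 `NC(=O)c1c(NC(=O)c2ccc(C(F)(F)F)cc2)sc2c1CCN(Cc1ccc(Cl)cc1Cl)C2` reaches only a limit of the assay, > 50000 nM (the limit of > 50000 nM in this assay, at which 1 of the 3 values shown sits). Among the numbers shown, compound 3 stands highest of the two, with compound 1 nearest and within the scatter. Compound 4 `NC(=O)c1c(NC(=O)c2cccc([N+](=O)[O-])c2)sc2c1CCN(C(=S)Nc1ccccc1Cl)C2` differs from compound 3 on the amine nitrogen in a ring: a group of 10 heavy atoms (7 carbon, 1 nitrogen, 1 sulfur, 1 chlorine; one six-membered aromatic ring of carbon only) in place of a group of 9 heavy atoms (7 carbon, 2 chlorine; one six-membered aromatic ring of carbon only), on an amine nitrogen in a ring. All measured steps, an at least 2.3-fold higher number from compound 1 to compound 2 (0.37 log units; beyond the scatter) and an at least 1.5-fold lower number from compound 2 to compound 3 (0.18 log units; that floor lies within the scatter) included, change the group on the carbonyl carbon, so none bears on this position. No direction beyond the scatter is expected. Compound 4 is estimated at 30000 nM, with a range from 8000 nM to 100000 nM. The expected step of a 1.1-fold lower number from compound 3 to compound 4 (0.04 log units; within the scatter) stays within the scatter.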

Compound 4, half-maximal inhibitory concentration: 40300 nM
For compound 4 the middle estimate is 1.3-fold (0.13 log units) below the measured one; the range from low to high includes it.
By their numbers in this assay, from the lowest: compounds 1, 3 and 4 (each within the scatter of the next). At a limit, above all of these: compound 2.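

The amine nitrogen in a ring now has a measured step of its own: with 3-nitrophenyl held on the carbonyl carbon, this assay shows a 1.2-fold higher number from compound 3 to compound 4 (0.09 log units; within the scatter) for this exchange. Here, 2,4-dichlorobenzyl and a group with a hydrogen-bond donor, a hydrogen-bond acceptor and a double bond outside aromatic rings cannot be told apart on this read-out. No measured property offers an explanation for this step.

Going by these compounds, how an acetyl group or a chain ending in a carboxylic acid would read on this nitrogen remains open. Also open, on these data alone, is whether the same exchange would read alike with 2-chlorophenyl on the carbonyl carbon.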